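The source may hold more compounds than are shown below. What is called first, only, known or untested is meant among the compounds shown, and "the series" means these compounds.

Measured in an ADME assay on cells (Erythrocyte, Homo sapiens) for activation, read by hemolysis, with a stated time of 30 min, tested at 1.25 mM; a higher number here means a stronger effect of the compound at the concentration tested, a lower number a weaker effect:
compound 1 `N=C(N)c1ccc(-c2ccc(-c3ccccc3)s2)s1` — "non-toxic" (no number reported)
compound 2 `COc1cccc(-c2ccc(-c3ccc(C(=N)N)s3)s2)c1` — 3.1%
compound 3 `N=C(N)c1ccc(-c2ccc(-c3ccc4ccccc4c3)s2)s1` — "non-toxic" (no number reported)

In this assay compound 1 stands without a single number; its result is given only in words, and compound 3 is recorded in the same way. Only compound 2 carries a figure, and that figure is small. Compound 4 `N=C(N)c1ccc(-c2ccc(-c3ccc(F)cc3)s2)s1` differs from compound 1 by fluoro in place of hydrogen on an aromatic carbon. Within the data shown here, no step between two measured compounds is available from which the size of this change could be read. Given that compound 2 gives 3.1% and the two other entries are described as without effect, the expectation for the step from compound 1 to compound 4 in this assay is no change beyond the usual scatter, in either direction. For compound 4 in this assay the expected value is 3%, with a range from 0% to 12%.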

Compound 4, a percentage reported as activity, at one concentration (the size of the read-out at that concentration, not a potency): "non-toxic" (no number reported)
No number was reported for compound 4; no gap can be computed for the estimate.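

In this assay, among these compounds, compound 1 and compound 4 are both recorded in words only, so no step between them can be read. No evidence bears on this result. The compounds shown leave open what size of effect, if any, fluoro in place of hydrogen has in this assay.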